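Chlorophenyl repositioning on the shared core, compound 4

The source may report more compounds than this note shows. Statements on the series, on what has been measured and on what is new or still open speak of the compounds shown alone.

Measured so far in an ADME assay on Vero cells (Chlorocebus sabaeus) for cytotoxicity, read by neutral red uptake, tested at 3150 ug/mL; on this read-out higher numbers stand for a weaker effect at the one concentration tested and lower numbers for a stronger effect:
compound 1 `O=C1CSC(c2cccc(F)c2)N1CCN1CCCCC1`: 13%
compound 2 `O=C1CSC(c2ccc(Cl)cc2)N1CCN1CCCCC1`: 11%
compound 3 `O=C1CSC(c2ccc(F)cc2)N1CCN1CCCCC1`: 11%

Compound 2 stands level with compound 3, the two together giving the lowest numbers of the three; the step of no change at the digits printed from compound 2 to compound 3 (within the scatter) is within the scatter. Compound 1 is the furthest of the set from compound 2, and the step of a number 2 percentage points lower from compound 1 to compound 2 (within the scatter) is also within the scatter. All three compounds share one core and differ only in the aryl group on the saturated ring carbon.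

Compound 4 `O=C1CSC(c2ccccc2Cl)N1CCN1CCCCC1` has not yet been measured. It differs from compound 2 by 2-chlorophenyl in place of 4-chlorophenyl on a saturated ring carbon.

Among the compounds with values here, three measured steps bear on this change, all of them aryl variations at the same place: a number 2 percentage points lower from compound 1 to compound 2 (within the scatter), a number 2 percentage points lower from compound 1 to compound 3 (within the scatter) and no change at the digits printed from compound 2 to compound 3 (within the scatter). None of them moves the read-out beyond the scatter, whether the halogen or its position on the aryl ring is altered. Moving the chloro to another aryl position in compound 4 is therefore expected to give no step beyond the scatter in this assay.

Compound 4 is estimated at 12%, with a range from 4% to 22%. This corresponds to an expected a number 1 percentage points higher from compound 2 to compound 4 (within the scatter), within the scatter.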

Compound 4, a percentage reported as activity, at one concentration (the size of the read-out at that concentration, not a potency): 22%
Estimate against measurement, compound 4: 10 percentage points below; low and high end bracket the measured number.
By their numbers in this assay, from the lowest: compounds 2, 3, 1 and 4 (each within the scatter of the next, the first and the last beyond it).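

In this assay, within the data shown here, the earlier aryl variations gave no step beyond the scatter, so this place on the saturated ring carbon looked insensitive to such changes; 2-chlorophenyl in place of 4-chlorophenyl, with the same atoms joined differently, now gives the first step beyond it (a number 11 percentage points higher from compound 2 to compound 4 (beyond the scatter)). Replacing 4-fluorophenyl with 2-chlorophenyl gives a step of the same kind (a number 11 percentage points higher from compound 3 to compound 4 (beyond the scatter)), which means a weaker effect at the one concentration tested, whereas the step from the 3-fluorophenyl group stays within the scatter (a number 9 percentage points higher from compound 1 to compound 4 (within the scatter)), so the separation holds only against the 4-chlorophenyl and 4-fluorophenyl compounds. No measurement shown here accounts for this difference between the isomers.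

As far as these compounds go, whether the step belongs to chloro in particular stays open, as a fluoro, methyl or methoxy group in place of the chloro of the 2-chlorophenyl group would be needed to tell. From the compounds shown here alone, with a single concentration in this assay, it also remains open whether the step between the isomers would persist at other concentrations, so these numbers should not be read as potencies.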